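Sulfur-Linked Methoxyphenyl Replaces a Dichlorophenoxy Group

This account rests on a few compounds, and the source may have more. Where it says the series, first, only, none or still open, it means among the compounds named here.

Compound 1 `Nc1cc(N)c2nc(-c3ccccc3)c(Oc3ccc(Cl)c(Cl)c3)nc2c1`: < 100000 nM, a limit of the assay.
Compound 2 `Nc1cc(N)c2nc(-c3ccccc3)c(NCc3ccc(Cl)c(Cl)c3)nc2c1`: < 100000 nM, a limit of the assay.
Compound 3 `COc1ccc(CNc2nc3cc(N)cc(N)c3nc2-c2ccccc2)cc1`: < 100000 nM, a limit of the assay.

From the compounds shown here alone, in a functional assay on NCI/ADR-RES cells (Homo sapiens) for inhibition, read by sulforhodamine B assay, with a stated time of 48 h (a lower number here means that less compound is tolerated, a higher number that more compound is tolerated), compound 1 gives only a limit, so where it truly stands is unknown. All three measured values share this feature: the limit of < 100000 nM in this assay, at which 3 of the 3 values shown sit. Among the compounds with values here, the single measured step, a step that the two limits leave unreadable from compound 2 to compound 3, runs between two limits and therefore has no readable size.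

Compound 4 `COc1ccc(Sc2nc3cc(N)cc(N)c3nc2-c2ccccc2)cc1` is the compound still to be measured; the change is (4-methoxyphenyl)sulfanyl in place of 3,4-dichlorophenoxy on an aromatic carbon. Within the data shown here, no measured step bears on this change, so nothing beyond the scatter can be predicted in this assay in either direction. Compound 4 is expected to give 30000 nM, within a range from 5000 nM to 100000 nM. The expected step is a step that the limit leaves unreadable from compound 1 to compound 4, with a fair chance that again only a limit is reported.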

Compound 4, concentration lethal to 50% of the cells: < 100000 nM
Compound 4: only a limit was reported (the forecaster's own chance of this, stated with the estimate: 40%); the middle value does not contradict the limit.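

Compound 1 and compound 4 each give only a limit, so no step between them can be read: the limit of < 100000 nM in this assay, at which 4 of the 4 values shown sit.

Where each compound truly stands, and whether (4-methoxyphenyl)sulfanyl in place of 3,4-dichlorophenoxy changes anything, stays open.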